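Swapping chlorines for methoxy groups on the ring-bound aryl

A few compounds are considered here, and "the series" means these few. Any claim that something is new, unique, unknown or untested is made for them only; others in the source may bear on it.

Of the compounds shown here, three of a shared core have been measured in a functional assay on HOP-92 cells (Homo sapiens) for cytotoxicity, read by sulforhodamine B assay, with a stated time of 48 h; on this read-out higher numbers stand for weaker inhibition of growth and lower numbers for stronger inhibition of growth. Compound 2 `O=C(N/N=c1\scc(-c2ccc(Cl)cc2)n1-c1ccc(Cl)cc1Cl)c1ccc(O)cc1` gives 7590 nM, the lowest of the three numbers. Compound 3 `Cc1ccc(-c2cs/c(=N\NC(=O)c3ccc(O)cc3)n2-c2c(C)cccc2C)cc1` gives 26300 nM, a step beyond the scatter from compound 2, and compound 1 `COc1ccc(-c2cs/c(=N\NC(=O)c3ccc(O)cc3)n2-c2ccc(OC)cc2OC)cc1` gives 37200 nM, further still. Compound 2 is thus the strongest grower inhibitor among these three, and the other two differ from it at more than one place, so no single change can be credited for the gap.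

Compound 4 `COc1ccc(-n2c(-c3ccc(Cl)cc3)cs/c2=N\NC(=O)c2ccc(O)cc2)c(OC)c1` has not yet been measured in this assay. It differs from compound 2 in one place: 2,4-dimethoxyphenyl in place of 2,4-dichlorophenyl on an aromatic nitrogen. Compound 1 carries the same 2,4-dimethoxyphenyl group on that nitrogen and stands well above compound 2, though it also differs elsewhere, so the comparison is only a hint.

The expectation for compound 4 is therefore a move toward weaker inhibition, a step from compound 2 to compound 4 of about a 2.6-fold higher number from compound 2 to compound 4 (0.42 log units; beyond the scatter) in this assay. The estimate for compound 4 in this assay is 20000 nM, with a likely range from 8000 nM to 50000 nM.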

Compound 4, concentration for total growth inhibition: 64600 nM
Estimate against measurement, compound 4: 3.2-fold (0.51 log units) below; measured number outside the range, above it.
By their numbers in this assay, from the lowest: compound 2; then compounds 3, 1 and 4 (each within the scatter of the next, the first and the last beyond it).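

In this assay, among the compounds shown here, with the 4-chlorophenyl group held fixed, 2,4-dimethoxyphenyl in place of 2,4-dichlorophenyl on the aromatic nitrogen gives an 8.5-fold higher number from compound 2 to compound 4 (0.93 log units; beyond the scatter) and so weaker inhibition of growth, the first clean evidence that the group at this position affects the read-out on its own. The other single change, chloro in place of methoxy on an aromatic carbon with 2,4-dimethoxyphenyl kept on the nitrogen, gives a 1.7-fold higher number from compound 1 to compound 4 (0.24 log units; within the scatter) and thus no readable difference, so in this pair the advantage of compound 2 does not come from that chlorine alone. Nothing measured here explains why the change on the nitrogen has such a large step.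

From the compounds shown here alone, it stays open whether both chlorines of the 2,4-dichlorophenyl group are needed, or whether one alone would keep the stronger inhibition seen with compound 2. The compounds shown also leave unknown how a plain phenyl group, a fluorine-bearing phenyl group or a phenyl group carrying an amine would read on that nitrogen.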